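The compounds below may be only part of what the source reports. "The series", "measured", "known", "first", "only" and "open" are said of these compounds alone.

Compound 1 `CNc1ccc2[nH]nc(C(=O)O)c2c1` stands only at a limit in an assay on isolated protein for inhibition of 2-Hydroxyacid oxidase 1 (Homo sapiens), with stated times of 30 min and 15 min; on this read-out lower numbers stand for stronger inhibition and higher numbers for weaker inhibition: in this assay compound 1 gives > 30000 nM, which is a limit of the assay rather than a number. Its value sits at the limit of > 30000 nM in this assay, at which 1 of the 2 values shown sits. Compound 2 `CN(C)c1noc(-c2cccc(CN(C)c3ccc4[nH]nc(C(=O)O)c4c3)c2O)n1` gives 21 nM in this assay. Compound 3 `O=C(O)c1n[nH]c2ccc(NCc3ccccc3)cc12` differs from compound 1 by phenyl in place of hydrogen on a saturated chain carbon bound to a nitrogen on an aromatic ring. Since compound 2, with far richer substitution, gives 21 nM, a gain beyond the scatter is expected on this step, estimated as an at least 10-fold lower number from compound 1 to compound 3 (1.00 log units; beyond the scatter). Compound 3 is expected to give 3000 nM in this assay, within a range from 500 nM to 20000 nM.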

Compound 3, half-maximal inhibitory concentration: 22000 nM
Estimate against measurement, compound 3: 7.3-fold (0.87 log units) below; measured number above the stated range.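

In this assay compound 3 gives 22000 nM, so phenyl on a saturated chain carbon bound to a nitrogen on an aromatic ring yields a measured number on the shared core. Compound 1 remains a limit and not a number: the limit of > 30000 nM in this assay, at which 1 of the 3 values shown sits. From the compounds shown here alone, the change can therefore be read only as an at least 1.3-fold lower number from compound 1 to compound 3 (0.13 log units; that floor lies within the scatter), and its true size stays unknown. The compounds shown leave open whether an amine or a carboxylic acid on the phenyl, or a longer chain at this place, would lower the number.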